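Notes on a ring-group swap: compound 3 to compound 4

A few compounds are considered here, and "the series" means these few. Any claim that something is new, unique, unknown or untested is made for them only; others in the source may bear on it.

Values in an ADME assay on microsomes from liver (Rattus norvegicus) for metabolic stability, using NADPH, with a stated time of 10 min; a higher number here means that more of the compound is left, a lower number that less of the compound is left:
- compound 1 `CN(C[C@H]1Cc2c(cccc2N2C[C@H]3CNC[C@H]3C2)CN1)[C@H]1CCCc2cccnc21`: 38.1%
- compound 2 `CN(C)[C@H]1CCN(c2cccc3c2C[C@H](CN(C)[C@H]2CCCc4cccnc42)NC3)C1`: 4.55%
- compound 3 `CN(C[C@H]1Cc2c(cccc2N2C[C@H]3CCN(C)[C@H]3C2)CN1)[C@H]1CCCc2cccnc21`: 11.2%

The series holds one high value and a low pair, and compound 3 belongs to that pair: a number 6.7 percentage points higher from compound 2 to compound 3 (within the scatter), and a number 26.9 percentage points lower from compound 1 to compound 3 (beyond the scatter).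

Compound 4 `CN1C[C@@H]2CN(c3cccc4c3C[C@H](CN(C)[C@H]3CCCc5cccnc53)NC4)C[C@@H]2C1` keeps the same atoms, joined differently: a group of 9 heavy atoms (7 carbon, 2 nitrogen; 2 five-membered non-aromatic rings with 1 hetero atom each) in place of a group of 9 heavy atoms (7 carbon, 2 nitrogen; 2 five-membered non-aromatic rings with 1 hetero atom each), on an aromatic carbon. Within the data shown here, no measured step covers this exact swap. The low pair shows that different groups here can give values within the scatter of each other. Compound 1 goes against this, with a large a number 33.6 percentage points lower from compound 1 to compound 2 (beyond the scatter) and a modest a number 26.9 percentage points lower from compound 1 to compound 3 (beyond the scatter), so some upward risk remains.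

The expected step is a number 1.8 percentage points higher from compound 3 to compound 4 (within the scatter), which would lie within the scatter. The estimate for compound 4 is 13%, with an expected range of 4% to 28%.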

Compound 4, percent of the compound remaining: 35.3%
For compound 4 the middle estimate is 22.3 percentage points below the measured one; measured number above the stated range.
By their numbers in this assay, from the lowest: compounds 2 and 3 (each within the scatter of the next); then compounds 4 and 1 (each within the scatter of the next).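

In this assay, the way the two five-membered rings are joined matters at this aromatic carbon, even with identical atoms: a number 24.1 percentage points higher from compound 3 to compound 4 (beyond the scatter), and a number 30.8 percentage points higher from compound 2 to compound 4 (beyond the scatter). Within the ring group of compound 4, methyl on the ring amine nitrogen costs nothing readable: a number 2.8 percentage points lower from compound 1 to compound 4 (within the scatter). Nothing available explains why the two isomeric groups part so far.

Open, from the compounds shown here alone, is whether an ethyl or acetyl on that ring nitrogen would keep the value of compound 4. Also open, going by these compounds, is whether the same joining holds with an oxygen in place of that nitrogen.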